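Hydroxamic Acid to Carboxylic Acid: Distribution Outlook

The source may report more compounds than this note shows. Statements on the series, on what has been measured and on what is new or still open speak of the compounds shown alone.

Measured so far:
compound 1 `C[C@@](CCc1ccc(-c2ccc(C#N)cc2)cc1)(C(=O)NO)S(C)(=O)=O` — 1.4 L/kg
compound 2 `C[C@@](CCc1ccc(-c2ccc(O)cc2)cc1)(C(=O)NO)S(C)(=O)=O` — 2.6 L/kg

In an in vivo ADME assay on the whole organism for pharmacokinetics, with Rattus norvegicus as the target, at a dose of 10 mg/kg by the intravenous route (a higher number here means that more of the compound sits outside the plasma, a lower number that more of the compound stays in the plasma), compound 1 gives 1.4 L/kg and compound 2 gives 2.6 L/kg. The two numbers sit within the scatter of each other, as the step of a 1.9-fold higher number from compound 1 to compound 2 (0.27 log units; within the scatter) shows, so compound 2 stands at one end of a pair that cannot be told apart.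

Compound 3 `C[C@@](CCc1ccc(-c2ccc(O)cc2)cc1)(C(=O)O)S(C)(=O)=O` differs from compound 2 by hydroxy in place of hydroxyamino on a carbonyl carbon. For the measured compounds named here, no measured step touches the carbonyl carbon; the only known step concerns an aromatic carbon. The expected step is a 5.2-fold lower number from compound 2 to compound 3 (0.72 log units; beyond the scatter), pointing to a lower number. Compound 3 is therefore estimated at 0.5 L/kg, with a range from 0.2 L/kg to 1.5 L/kg.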

Compound 3, volume of distribution at steady state: 0.4 L/kg
For compound 3 the middle estimate is 1.3-fold (0.10 log units) above the measured one; low and high end bracket the measured number.
By their numbers in this assay, from the lowest: compound 3; then compounds 1 and 2 (each within the scatter of the next).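

For the compounds shown here, changing hydroxycarbamoyl to carboxy on the carbonyl carbon gives a 6.5-fold lower number from compound 2 to compound 3 (0.81 log units; beyond the scatter) in this assay, the only step so far beyond the scatter. Going by these compounds alone, the earlier step, on an aromatic carbon, stayed within the scatter, so the carbonyl position is the one place where the number has clearly moved. Nothing available explains this shift. As far as these compounds go, it remains open whether the same change would give a similar step with the nitrile of compound 1 in place of the hydroxy. An amide or a methyl ester on that carbonyl carbon also remains untested among the compounds shown here.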